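From methoxy to trifluoromethoxy on a shared core

The source may hold more compounds than are shown below. What is called first, only, known or untested is meant among the compounds shown, and "the series" means these compounds.

Values from a functional assay on K562 cells (Homo sapiens) for antiproliferative activity, with a stated time of 72 h (on this read-out higher numbers stand for weaker inhibition and lower numbers for stronger inhibition), stand as follows:

compound 1 (`OC[C@H]1O[C@@H](n2cnc3c(NCc4cccc(F)c4)ncnc32)[C@H](O)[C@@H]1O`) gives 7600 nM
compound 2 (`COc1cccc(CNc2ncnc3c2ncn3[C@@H]2O[C@H](CO)[C@@H](O)[C@H]2O)c1`) gives > 166000 nM as a limit
compound 3 (`OC[C@H]1O[C@@H](n2cnc3c(NCc4ccc(F)cc4F)ncnc32)[C@H](O)[C@@H]1O`) gives 9600 nM

Compound 2 stands at > 166000 nM, which is a limit and not a number, the weakest result of the three. Compound 4 (`OC[C@H]1O[C@@H](n2cnc3c(NCc4cccc(OC(F)(F)F)c4)ncnc32)[C@H](O)[C@@H]1O`) differs from compound 2 by trifluoromethyl in place of methyl on an oxygen on an aromatic ring. Among the compounds with values here, two measured steps bear on this: an at least 21-fold higher number from compound 1 to compound 2 (1.33 log units; beyond the scatter) and an at least 17-fold lower number from compound 2 to compound 3 (1.23 log units; beyond the scatter), both large. Within the data shown here, compound 4 keeps the oxygen of compound 2 but carries fluorine, as compound 1 and compound 3 do, though no measured step tests this exact change. The expected step is an at least 8.3-fold lower number from compound 2 to compound 4 (0.91 log units; beyond the scatter), large and towards stronger inhibition. The estimate for compound 4 is 20000 nM (expected range 5000 nM to 100000 nM).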

Compound 4, half-maximal inhibitory concentration: > 166000 nM
Compound 4 was reported as a limit; the forecaster's own chance of this, stated with the estimate: 20%; at least 8.3-fold (0.91 log units) between middle value and limit.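

In this assay, trifluoromethoxy in place of fluoro on an aromatic carbon gives an at least 21-fold higher number from compound 1 to compound 4 (1.33 log units; beyond the scatter) and so does not bring back the activity of compound 1, even though the new group carries fluorine. Compound 2 and compound 4 are both reported only as limits, so the step between them cannot be read. Fluorine on the oxygen therefore gives no measurable gain in this assay: the limit of > 166000 nM in this assay, at which 2 of the 4 values shown sit.

On these data alone, it remains open whether the loss follows the oxygen on the ring or any group other than fluoro. A chloro or methyl on the same aromatic carbon would separate these two readings.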